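A few compounds are considered here, and "the series" means these few. Any claim that something is new, unique, unknown or untested is made for them only; others in the source may bear on it.

Of the compounds shown here, three sharing one core have been measured in a functional assay (aorta) for inhibition, with Rattus norvegicus as the target; a higher number here means that more compound is needed for the effect, a lower number that less compound is needed. Compound 1 (`O=C1C=C(Nc2ccc(F)cc2)C(=O)c2cnccc21`) gives 1230 nM, compound 2 (`O=C1C=C(Nc2ccc(F)c(F)c2)C(=O)c2cnccc21`) gives 640 nM and compound 3 (`O=C1C=C(Nc2ccc(F)cc2F)C(=O)c2cnccc21`) gives 430 nM. Compound 3 thus lies within the usual scatter of compound 2 and beyond the scatter of compound 1. Compound 4 (`O=C1C=C(Nc2ccc(F)c(F)c2F)C(=O)c2cnccc21`) differs from compound 3 by one change: fluoro in place of hydrogen on an aromatic carbon. Two measured steps are of this kind: a 1.9-fold lower number from compound 1 to compound 2 (0.28 log units; within the scatter) and a 2.9-fold lower number from compound 1 to compound 3 (0.46 log units; beyond the scatter). Among the compounds with values here, both lead to a lower number, but both start from compound 1, and no measured step starts from compound 3. In this assay, only a small further move towards a lower number is therefore expected, not one beyond the scatter. The expected step is a 1.3-fold lower number from compound 3 to compound 4 (0.10 log units; within the scatter). For compound 4, the estimated value is 340 nM, with an expected range from 150 nM to 750 nM.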

Compound 4, half-maximal effective concentration: 1130 nM
Compound 4: the middle estimate sits 3.3-fold (0.52 log units) below what was measured; the measured number lies above the stated range.
By their numbers in this assay, from the lowest: compounds 3, 2, 4 and 1 (each within the scatter of the next, the first and the last beyond it).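

In this assay, fluoro in place of hydrogen does not keep lowering the number once the ring already carries two fluoro groups: placed ortho to two fluoro groups, it gives a 2.6-fold higher number from compound 3 to compound 4 (0.42 log units; beyond the scatter), and the step from the other difluoro compound gives a 1.8-fold higher number from compound 2 to compound 4 (0.25 log units; within the scatter). The same change therefore has no single effect here, and its direction depends on the fluoro groups already present, as the first comparison shows: the same change on two cores in this assay, a 1.9-fold lower number (0.28 log units; within the scatter) from compound 1 to compound 2 and a 2.6-fold higher number (0.42 log units; beyond the scatter) from compound 3 to compound 4, 5.1-fold (0.70 log units) apart, beyond the scatter of two such steps The second comparison points the same way: the same change on two cores in this assay, a 2.9-fold lower number (0.46 log units; beyond the scatter) from compound 1 to compound 3 and a 1.8-fold higher number (0.25 log units; within the scatter) from compound 2 to compound 4, 5.1-fold (0.70 log units) apart, beyond the scatter of two such steps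

The compounds shown carry only hydrogen or fluoro on this ring, which leaves open how chloro, methyl or methoxy at this position would behave. They also cannot separate an effect of this position alone from an effect of the whole set of fluoro groups in compound 4.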